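Replacing 3-(trifluoromethyl)phenyl with 2-bromophenyl on a shared core

The source may hold more compounds than are shown below. What is called first, only, known or untested is meant among the compounds shown, and "the series" means these compounds.

Of the compounds shown here, three sharing one core have been measured in a functional assay on SW-620 cells (Homo sapiens) for cytotoxicity, read by MTT assay, with stated times of 4 h and 72 h, tested at 5 uM; a higher number here means a weaker inhibitor, a lower number a stronger inhibitor. Compound 1 `Cc1cc(Nc2ccc(C(=O)/C=C/c3ccc4ccccc4c3)cc2)n2nc(SCc3ccc([N+](=O)[O-])cc3)nc2n1`, which carries 4-nitrophenyl on a saturated chain carbon bound to a sulfur, gives 1130 nM. Compound 2 `Cc1cc(Nc2ccc(C(=O)/C=C/c3ccc4ccccc4c3)cc2)n2nc(SCc3ccccc3)nc2n1`, with no substituent on that aromatic ring, gives 300 nM. Compound 3 `Cc1cc(Nc2ccc(C(=O)/C=C/c3ccc4ccccc4c3)cc2)n2nc(SCc3cccc(C(F)(F)F)c3)nc2n1` gives 2070 nM, which stands close to the nitro compound, with a 1.8-fold higher number from compound 1 to compound 3 (0.26 log units; within the scatter). Its distance from the unsubstituted compound is larger, with a 6.9-fold higher number from compound 2 to compound 3 (0.84 log units; beyond the scatter).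

Compound 4 `Cc1cc(Nc2ccc(C(=O)/C=C/c3ccc4ccccc4c3)cc2)n2nc(SCc3ccccc3Br)nc2n1` has not yet been measured, and it differs from compound 3 as follows: 2-bromophenyl in place of 3-(trifluoromethyl)phenyl on a saturated chain carbon bound to a sulfur. Within the data shown here, two measured steps bear on this change. Hydrogen in place of nitro gave a 3.8-fold lower number from compound 1 to compound 2 (0.58 log units; beyond the scatter), and trifluoromethyl in place of hydrogen gave a 6.9-fold higher number from compound 2 to compound 3 (0.84 log units; beyond the scatter). Among the measured compounds shown here, in both cases the substituted compound carries the higher number, but neither case involves bromine, and no compound measured so far has a substituent at the position named in 2-bromophenyl. Compound 4 is therefore expected to lie nearer compounds 1 and 3 than compound 2, with only a small shift from compound 3. The expected step is a 2.1-fold lower number from compound 3 to compound 4 (0.32 log units; beyond the scatter). For compound 4 the estimated value is 1000 nM, with an expected range of 350 nM to 2800 nM.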

Compound 4, half-maximal inhibitory concentration: 420 nM
Compound 4: the middle estimate sits 2.4-fold (0.38 log units) above what was measured, within the range that was stated.
By their numbers in this assay, from the lowest: compounds 2 and 4 (each within the scatter of the next); then compounds 1 and 3 (each within the scatter of the next).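

In this assay, the change at this position is not neutral among substituted rings: 2-bromophenyl in place of 3-(trifluoromethyl)phenyl gives a 4.9-fold lower number from compound 3 to compound 4 (0.69 log units; beyond the scatter), and 2-bromophenyl in place of 4-nitrophenyl gives a 2.7-fold lower number from compound 1 to compound 4 (0.43 log units; beyond the scatter). Until now, both substituted rings had carried a number beyond the scatter from that of the unsubstituted compound, but bromo in place of hydrogen gives only a 1.4-fold higher number from compound 2 to compound 4 (0.15 log units; within the scatter), so among these four compounds a substituent on this aromatic ring does not by itself set the number apart, with compound 4 going against what compound 1 and compound 3 had suggested. No measurement bears on why these groups differ in this way.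

Since 2-bromophenyl differs from the other two substituted rings in both the group and where it sits, the compounds shown do not separate the contribution of bromo from that of its place on the ring. On these data alone, how a ring bearing an amine or a carboxylic acid, or a longer chain in place of the saturated chain carbon bound to a sulfur, would read in this assay also stays open.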